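Plasma half-life across esters on the shared core

A few compounds are considered here, and "the series" means these few. Any claim that something is new, unique, unknown or untested is made for them only; others in the source may bear on it.

Compound 2 `CCCCC(=O)O[C@@H]1CO[C@H]2[C@@H]1OC[C@@H]2OC(=O)c1ccccc1OC(C)=O` gives 0.0198 h in an ADME assay on a cell-free system (plasma, Homo sapiens) for metabolic stability, with Plasma (Rattus norvegicus) as the target, read by HPLC, at pH 7.4 (on this read-out lower numbers stand for a shorter-lived compound and higher numbers for a longer-lived compound), the lowest of the three numbers recorded so far. Compound 1 `CC(=O)Oc1ccccc1C(=O)O[C@H]1CO[C@H]2[C@@H]1OC[C@H]2OC(=O)c1snnc1C` gives 0.0642 h, and compound 3 `CC(=O)Oc1ccccc1C(=O)O[C@H]1CO[C@H]2[C@@H]1OC[C@H]2OC(=O)c1cnoc1C` gives 0.193 h. The three measured steps all concern the group on the same carbonyl carbon: a 3.2-fold lower number from compound 1 to compound 2 (0.51 log units; beyond the scatter), a 3.0-fold higher number from compound 1 to compound 3 (0.48 log units; beyond the scatter) and a 9.7-fold higher number from compound 2 to compound 3 (0.99 log units; beyond the scatter).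

Compound 4 `CC(=O)Oc1ccccc1C(=O)O[C@H]1CO[C@H]2[C@@H]1OC[C@H]2OC(=O)CCO[N+](=O)[O-]` is not yet measured. It differs from compound 2 by nitrooxy in place of ethyl on a saturated chain carbon, two bonds along the chain from a carbonyl carbon. Among the measured compounds shown here, no measured step exchanges ethyl for nitrooxy, and the three steps above only show that exchanging the group on this carbonyl carbon moves the half-life modestly in either direction; none of them places compound 2 together with an acyl group carrying nitrooxy. The expected step is therefore modest and its direction uncertain, with a slight lean upward because compound 2 gives 0.0198 h, the lowest number, so a 2.0-fold higher number from compound 2 to compound 4 (0.31 log units; beyond the scatter) is expected. Compound 4 is estimated at 0.04 h, in a range from 0.01 h to 0.15 h.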

Compound 4, half-life: 0.065 h
For compound 4 the middle estimate is 1.6-fold (0.21 log units) below the measured one; the measured number falls inside the stated range.
By their numbers in this assay, from the lowest: compound 2; then compounds 1 and 4 (each within the scatter of the next); then compound 3.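

A saturated chain on this carbonyl carbon does not by itself hold the half-life at the bottom of the series: nitrooxy in place of ethyl gives a 3.3-fold higher number from compound 2 to compound 4 (0.52 log units; beyond the scatter) with the chain still attached at the same place. The 2-(nitrooxy)ethyl group matches 4-methyl-1,2,3-thiadiazol-5-yl, with a 1.0-fold higher number from compound 1 to compound 4 (0.01 log units; within the scatter) as the whole difference, but it does not reach 5-methyl-1,2-oxazol-4-yl, with a 3.0-fold lower number from compound 3 to compound 4 (0.47 log units; beyond the scatter) on that side. No measurement here explains these shifts.

Open, going by these compounds, is whether nitrooxy itself is what counts, or whether a hydroxyl or a carboxylic acid at the same chain position would give a similar half-life. Also open, on these data alone, are how a longer chain carrying nitrooxy would compare and which ester on the shared core is cleaved first.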